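Trifluoromethyl for Methyl on the Benzamide of Compound 3

The source may hold more compounds than are shown below. What is called first, only, known or untested is meant among the compounds shown, and "the series" means these compounds.

Compound 3 `COc1ccc2sc(NC(=O)c3ccc(C)cc3)nc2c1` gives only a limit, not a number, in a functional assay on NUGC-3 cells (Homo sapiens) for antiproliferative activity, read by sulforhodamine B assay; a higher number here means a weaker inhibitor of growth, a lower number a stronger inhibitor of growth: compound 3 reads > 10 ug/mL. Compound 2 `COc1ccc(C(=O)Nc2nc3cc(C)cc(C)c3s2)cc1` likewise returns only a limit in this assay, namely > 10 ug/mL. Compound 1 `O=C(Nc1nc2ccc([N+](=O)[O-])cc2s1)c1ccc(C(F)(F)F)cc1`, which carries a trifluoromethyl on its benzamide, gives 1.65 ug/mL in this assay. Within the data shown here, two of the three values thus sit at the limit of > 10 ug/mL in this assay, at which 2 of the 3 values shown sit, so compound 3 has no measured number to step from. Compound 4 `COc1ccc2sc(NC(=O)c3ccc(C(F)(F)F)cc3)nc2c1` differs from compound 3 by trifluoromethyl in place of methyl on an aromatic carbon. Among the measured compounds shown here, no step between measured compounds is known; the only hint is that compound 1 at 1.65 ug/mL gives the single numerical value among the three and carries a trifluoromethyl. The step from compound 3 to compound 4 is therefore expected to be an at least 1.6-fold lower number from compound 3 to compound 4 (0.22 log units; that floor lies within the scatter). Compound 4 is estimated at 6 ug/mL, between 2 ug/mL and 15 ug/mL.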

Compound 4, concentration for 50% growth inhibition: > 10 ug/mL
Compound 4: no number, only a limit (the forecaster's own chance of this, stated with the estimate: 45%); middle value at least 1.6-fold (0.22 log units) away from the limit.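

Among these compounds, compound 3 and compound 4 both return only a limit in this assay, so no step between them can be read: the limit of > 10 ug/mL in this assay, at which 3 of the 4 values shown sit. Going by these compounds, whether trifluoromethyl in place of methyl on an aromatic carbon changes growth inhibition here remains open.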